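Changing the aryl group leaves the numbers level

This account rests on a few compounds, and the source may have more. Where it says the series, first, only, none or still open, it means among the compounds named here.

Compound 1 `CCC1=C(O)c2c(oc(-c3ccc(COC)cc3)cc2=O)C(CC)(CC)C1=O`: 3.4 uM
Compound 2 `CCC1=C(O)c2c(oc(-c3cccc(F)c3)cc2=O)C(CC)(CC)C1=O`: 3.09 uM
Compound 3 `CCC1=C(O)c2c(oc(-c3cc(C)ccc3C)cc2=O)C(CC)(CC)C1=O`: 3.41 uM

In a functional assay on KBVIN cells (Homo sapiens) for antiproliferative activity, read by sulforhodamine B assay, with a stated time of 3 days (a higher number here means that more compound is needed for the effect, a lower number that less compound is needed), compound 3 gives 3.41 uM and stands level with the other two compounds, within the scatter. Compound 4 `CCC1=C(O)c2c(oc(-c3ccc(F)c(C)c3)cc2=O)C(CC)(CC)C1=O` has not yet been measured. It shares the core of compound 3 but has 4-fluoro-3-methylphenyl in place of 2,5-dimethylphenyl on an aromatic carbon next to the ring oxygen 4-fluoro-3-methylphenyl in place of 2,5-dimethylphenyl on an aromatic carbon and differs nowhere else.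

Three measured swaps at this same place bear on the change. They are a 1.1-fold lower number from compound 1 to compound 2 (0.04 log units; within the scatter) and a 1.0-fold higher number from compound 1 to compound 3 (0.00 log units; within the scatter) and also a 1.1-fold higher number from compound 2 to compound 3 (0.04 log units; within the scatter) and none of them leaves the scatter. The three compounds carry quite different aryl groups, yet the numbers stay together. The step of a 1.0-fold lower number from compound 3 to compound 4 (0.01 log units; within the scatter) is therefore expected to stay within the scatter, with no direction to be read from the data. In this assay the estimate for compound 4 is 3.3 uM (expected range 1.8 uM to 6 uM).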

Compound 4, concentration for half-maximal effect: 1.62 uM
For compound 4 the middle estimate is 2.0-fold (0.31 log units) above the measured one; measured number outside the range, below it.
By their numbers in this assay, from the lowest: compounds 4, 2, 1 and 3 (each within the scatter of the next, the first and the last beyond it).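

In this assay, this position, which had looked indifferent to the choice of aryl group, does respond to it: a 2.1-fold lower number from compound 3 to compound 4 (0.32 log units; beyond the scatter) and a 2.1-fold lower number from compound 1 to compound 4 (0.32 log units; beyond the scatter) both lie beyond the scatter, though only modestly. The step of a 1.9-fold lower number from compound 2 to compound 4 (0.28 log units; within the scatter) stays within the scatter, so the 4-fluoro-3-methylphenyl group is not set apart from every other aryl group shown. Nothing among the data bears on what lies behind this separation.

The compounds shown leave open which of the two substituents in the 4-fluoro-3-methylphenyl group carries the separation. They also leave open how this position would respond to an amine or a carboxylic acid on the phenyl ring.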